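Chain-linked amide series: expectation for compound 4

A few compounds are considered here, and "the series" means these few. Any claim that something is new, unique, unknown or untested is made for them only; others in the source may bear on it.

Among the compounds with values here, in an assay on isolated protein (Mus musculus) for inhibition of IL15-IL15 receptor (Homo sapiens), read by resazurin assay, with stated times of 30 min and 2.5 days (on this read-out lower numbers stand for stronger inhibition and higher numbers for weaker inhibition), compound 2 `Cn1c(Cc2nn(C)c(=O)c3ccccc23)nnc1SCCCCCCCCCCC(=O)Nc1ccccc1Cl` gives 15000 nM, the only number. Compound 1 `CCCOc1ccc(NC(=O)CSc2nnc(Cc3nn(C)c(=O)c4ccccc34)n2C)cc1` reaches only the limit of > 30000 nM. Compound 3 `Cn1c(Cc2nn(C)c(=O)c3ccccc23)nnc1SCCCCCCCC(=O)Nc1ccc(O)cc1` likewise reaches only the limit of > 30000 nM. Two of the three values therefore sit at the limit of > 30000 nM in this assay, at which 2 of the 3 values shown sit. Compound 4 `Cn1c(Cc2nn(C)c(=O)c3ccccc23)nnc1SCCCCCCCCCC(=O)Nc1ccc(Cl)cc1Cl` carries (2,4-dichlorophenyl)carbamoyl in place of ((2-chlorophenyl)carbamoyl)methyl on a saturated chain carbon, nine bonds along the chain from a sulfur relative to compound 2. Within the data shown here, no step between measured compounds covers this change, so the expectation rests on compound 2 alone. No step beyond the usual scatter is expected in either direction in this assay. Compound 4 is estimated at 15000 nM, with a range from 5000 nM to 40000 nM. The expected step is no change at the digits printed from compound 2 to compound 4 (within the scatter), with a real chance that only a limit is reported.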

Compound 4, half-maximal inhibitory concentration: 2300 nM
Compound 4: middle estimate off by 6.5-fold (0.81 log units), on the high side; measured number outside the range, below it.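

The series now has one readable step, and it comes from the far end of the chain: a 6.5-fold lower number from compound 2 to compound 4 (0.81 log units; beyond the scatter) in this assay. That step joins a shorter chain to an added chlorine, so it cannot be assigned to either alone. Steps involving compound 1 or compound 3 cannot be read: the limit of > 30000 nM in this assay, at which 2 of the 4 values shown sit.

Still open, from the compounds shown here alone, is whether the chain or the chlorine carries the step, which would take the 2,4-dichlorophenyl amide on a longer chain, or the 2-chlorophenyl amide on the shorter one. Going by these compounds, whether a carboxylic acid or an amine on that ring would be tolerated also remains open.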